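A few compounds are considered here, and "the series" means these few. Any claim that something is new, unique, unknown or untested is made for them only; others in the source may bear on it.

Of the compounds shown here, three have so far been tested in an ADME assay on MT2 cells (Homo sapiens) for cytotoxicity; a higher number here means that more compound is tolerated, a lower number that less compound is tolerated.

Compound 1, `CCc1cc(CNC(=O)c2cc3nc(C)c([C@H](OC(C)(C)C)C(=O)O)c(-c4cc(F)c5c(c4C)CCCO5)n3n2)ccc1F`, gives > 40000 nM, which is a limit of the assay.
Compound 2, `COc1cc(CNC(=O)c2cc3nc(C)c([C@H](OC(C)(C)C)C(=O)O)c(-c4cc(F)c5c(c4C)CCCO5)n3n2)ccc1F`, gives > 20000 nM, which is a limit of the assay.
Compound 3, `COc1cc(F)ccc1CNC(=O)c1cc2nc(C)c([C@H](OC(C)(C)C)C(=O)O)c(-c3cc(F)c4c(c3C)CCCO4)n2n1`, gives > 40000 nM, which is a limit of the assay.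

Compound 3 therefore stands at the upper edge of what this assay can report, and the two other values shown are limits as well. The step from compound 1 to compound 2, a step that the two limits leave unreadable from compound 1 to compound 2, the step from compound 1 to compound 3, a step that the two limits leave unreadable from compound 1 to compound 3, and the step from compound 2 to compound 3, a step that the two limits leave unreadable from compound 2 to compound 3, are all unreadable, as the limit of > 20000 nM in this assay, at which 1 of the 3 values shown sits, and the limit of > 40000 nM in this assay, at which 2 of the 3 values shown sit, make plain.

Compound 4, `CCCNC(=O)c1cc2nc(C)c([C@H](OC(C)(C)C)C(=O)O)c(-c3cc(F)c4c(c3C)CCCO4)n2n1`, differs from compound 3 in one place: ethyl in place of 4-fluoro-2-methoxyphenyl on a saturated chain carbon bound to an amide-type nitrogen. Among the compounds with values here, none of the measured steps bears directly on this change, since all three concern exchanges among 3-ethyl-4-fluorophenyl, 4-fluoro-3-methoxyphenyl and 4-fluoro-2-methoxyphenyl at the same position, and none of them could be read. With every measured compound sitting at a limit, the expected step from compound 3 to compound 4 in this assay is a number no higher from compound 3 to compound 4 (the limit leaves the size open), that is, none beyond the scatter. Compound 4 is estimated at 40000 nM, with a range from 20000 nM to 80000 nM, and is expected to be reported again only as a limit.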

Compound 4, half-maximal cytotoxic concentration: > 40000 nM
Compound 4: a limit, no number (the forecaster's own chance of this, stated with the estimate: 85%); the middle value sits exactly at the limit.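

Compound 4 is again reported only as a limit, so no step from compound 1, compound 2 or compound 3 to compound 4 can be read: the limit of > 40000 nM in this assay, at which 3 of the 4 values shown sit.

The compounds shown leave open whether 4-fluoro-2-methoxybenzyl to propyl, or any other change among them, alters the tolerated concentration at all.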